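From Fluoro to Cyano in a Small Antiproliferative Series

The source may report more compounds than this note shows. Statements on the series, on what has been measured and on what is new or still open speak of the compounds shown alone.

Three compounds built on a shared core have been run through a functional assay on HL-60 cells (Homo sapiens) for antiproliferative activity, read by sulforhodamine B assay, with a stated time of 72 h (on this read-out higher numbers stand for weaker inhibition and lower numbers for stronger inhibition), so far. Compound 1 `S=C(NNc1nncc2ccccc12)Nc1ccccc1` comes in at 95 nM and compound 2 `O=S(=O)(Nc1ncccn1)c1ccc(Nc2nncc3ccccc23)cc1` at 67 nM while compound 3 `Fc1ccc(Nc2nncc3ccccc23)cc1` reaches 6.4 nM as the lowest number of the three. The gaps from compound 3 to both of the others lie beyond the scatter of repeated measurements.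

The next compound changes one small group. Compound 4 `N#Cc1ccc(Nc2nncc3ccccc23)cc1` carries cyano in place of fluoro on an aromatic carbon and has not yet been measured. The swap sits para to a large group. Within the data shown here, no two measured compounds differ in just one place, so the data offer no direct guide to this change. Starting from compound 3 at 6.4 nM as the reference, a modest rise toward weaker inhibition in this assay is expected, not far beyond the scatter. The expected change is a 1.9-fold higher number from compound 3 to compound 4 (0.27 log units; within the scatter) as an estimate only. For compound 4 the estimate is 12 nM with an expected range of 3 nM to 60 nM in this measurement.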

Compound 4, half-maximal inhibitory concentration: 5.5 nM
Beside the measured number, compound 4's estimate is 2.2-fold (0.34 log units) above it; the measured number falls inside the stated range.
By their numbers in this assay, from the lowest: compounds 4 and 3 (each within the scatter of the next); then compounds 2 and 1 (each within the scatter of the next).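

In this assay, replacing fluoro with cyano on an aromatic carbon, para to a large group, gives a 1.2-fold lower number from compound 3 to compound 4 (0.07 log units; within the scatter), so the two compounds cannot be told apart. This is the first pair shown that differs in one place, and it gives a direct reading at this position: cyano, with two heavy atoms and one hydrogen-bond acceptor, keeps the number at the level seen with fluoro, which has one heavy atom and no acceptor. Nothing measured here explains why these two groups read alike.

On these data alone, two groups at one position set no rule, so it remains open whether an amine, a carboxylic acid or a longer chain placed there would hold the number at this level. As far as these compounds go, it also remains open whether the match between these two compounds would carry over to other cell lines.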